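From tert-Butyl to 4-Methylbenzyl on the Amide Nitrogen

The source may hold more compounds than are shown below. What is called first, only, known or untested is meant among the compounds shown, and "the series" means these compounds.

Measured compounds:
compound 1 `C=CC1=C(C(=O)NCCC)C(c2ccc(Cl)c(Cl)c2)OC1` — > 100000 nM
compound 2 `C=CC1=C(C(=O)NC(C)(C)C)C(c2ccc(OC)cc2)OC1` — > 100000 nM
compound 3 `C=CC1=C(C(=O)NC(C)(C)C)C(c2ccc(F)cc2)OC1` — > 100000 nM

Three compounds on the shared core have been run in a functional assay on A549 cells (Homo sapiens) for cytotoxicity, read by MTT assay, with a stated time of 24 h; on this read-out lower numbers stand for stronger inhibition and higher numbers for weaker inhibition. Compound 1 gives > 100000 nM, which is a limit of the assay and not a number. Compound 2 likewise gives > 100000 nM, again only a limit. Compound 3 gives > 100000 nM, a limit as well. So compound 2 stands where every measured compound stands: at the limit, with no number to place it above or below the others. Among the measured compounds shown here, the single one-place step among them, a step that the two limits leave unreadable from compound 2 to compound 3, cannot be read for size or direction. For the measured compounds named here, the only evidence that can be pointed to is the limit of > 100000 nM in this assay, at which 3 of the 3 values shown sit.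

Compound 4 `C=CC1=C(C(=O)NCc2ccc(C)cc2)C(c2ccc(OC)cc2)OC1` differs from compound 2 by 4-methylbenzyl in place of tert-butyl on an amide-type nitrogen. Going by the values given here, no measured step touches this amide nitrogen, so nothing here shows how large a step in this assay to expect from this change, nor its direction. Given that compound 2 sits at > 100000 nM, compound 4 is expected to remain in the same region, most likely reported again as a limit. The estimate for compound 4 is 150000 nM, with a range from 40000 nM to 500000 nM. The expected step that the limit leaves unreadable from compound 2 to compound 4 is therefore none beyond the scatter.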

Compound 4, half-maximal inhibitory concentration: > 100000 nM
Compound 4: a limit, no number (the forecaster's own chance of this, stated with the estimate: 80%); the middle value does not contradict the limit.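

In this assay compound 4 gives > 100000 nM, a limit of the assay and not a number. Compound 2 also stands at a limit, so the change from compound 2 to compound 4 cannot be read for size or direction. The compounds shown leave open whether any change on the shared core gives a measurable value in this assay.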